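The source may hold more compounds than are shown below. What is called first, only, known or untested is meant among the compounds shown, and "the series" means these compounds.

Measured so far:
compound 1, `COc1ccc(-c2cc3cc(C4C(C#N)=C(N)OC5=C4C(=O)CCC5)cc(C(C)C)c3oc2=O)cc1`: 69.7%
compound 2, `COc1ccc(-c2cc3cc(C4C(C#N)=C(N)OC5=C4C(=O)CCC5)cc(C(C)C)c3oc2=O)cc1OC`: 57.2%
compound 3, `COc1ccc(-c2cc3cc(C4C(C#N)=C(N)OC5=C4C(=O)CCC5)cc(C(C)(C)C)c3oc2=O)cc1`: 30.7%

In a functional assay on the whole organism (strain Swiss albino) with Mus musculus as the target, in the forced swim test, with a stated time of 5 min, at a dose of 0.5 mg/kg by the intraperitoneal route (on this read-out lower numbers stand for less inhibition and higher numbers for more inhibition at the one dose given (going by the name of the read-out)), compound 3 stands lowest of the three numbers. Compound 2 lies nearest to it and compound 1 furthest, and both gaps are beyond the scatter; the step of a number 39 percentage points lower from compound 1 to compound 3 (beyond the scatter) describes the distance to compound 1 directly.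

Compound 4, `COc1ccc(-c2cc3cc(C4C(C#N)=C(N)OC5=C4C(=O)CCC5)cc(C(C)(C)C)c3oc2=O)cc1OC`, differs from compound 3 in one place: methoxy in place of hydrogen on an aromatic carbon. The same change has been measured once before, on a different partner: the step of a number 12.5 percentage points lower from compound 1 to compound 2 (beyond the scatter), a modest fall beyond the scatter. The step of a number 39 percentage points lower from compound 1 to compound 3 (beyond the scatter) shows that compound 3 already starts from a low number, so the same modest fall would leave little room before the read-out reaches the bottom of its range.

Carrying the earlier fall over, the expected step is a number 11.7 percentage points lower from compound 3 to compound 4 (beyond the scatter). Compound 4 is therefore estimated to give 19% in this assay, with a range from 4% to 34%.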

Compound 4, a percentage reported as inhibition, in the whole organism at one dose (the size of the read-out at that dose, not a potency): -16.6%
Compound 4: the middle estimate sits 35.6 percentage points above what was measured; the whole stated range lies above it.
By their numbers in this assay, from the lowest: compound 4; then compound 3; then compound 2; then compound 1.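

The change from 4-methoxyphenyl to 3,4-dimethoxyphenyl has no fixed cost in this assay; its size depends on what the rest of the molecule carries: the same change on two cores in this assay, a number 12.5 percentage points lower (beyond the scatter) from compound 1 to compound 2 and a number 47.3 percentage points lower (beyond the scatter) from compound 3 to compound 4, 34.8 percentage points apart, beyond the scatter of two such steps Read the other way, the added methyl on the saturated chain carbon also costs more once the second methoxy is present, with a number 73.8 percentage points lower from compound 2 to compound 4 (beyond the scatter), and a number 47.3 percentage points lower from compound 3 to compound 4 (beyond the scatter) is the matching step for the methoxy, so the two changes do not simply add up: the same change on two cores in this assay, a number 39 percentage points lower (beyond the scatter) from compound 1 to compound 3 and a number 73.8 percentage points lower (beyond the scatter) from compound 2 to compound 4, 34.8 percentage points apart, beyond the scatter of two such steps Compound 4, at -16.6%, also shows that this read-out does not stop at zero.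

On these data alone, whether the sharp fall belongs to methoxy itself remains open, since a hydroxy group or a fluorine on the same aromatic carbon would be needed to tell. As far as these compounds go, it is equally open how an ethyl group on the core would behave alongside the 3,4-dimethoxyphenyl.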